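Halogen swap on the benzyl group and expected cytotoxicity

The source may report more compounds than this note shows. Statements on the series, on what has been measured and on what is new or still open speak of the compounds shown alone.

Compound 1 `O=c1ccoc2cc(OCc3cn(Cc4ccccc4)nn3)ccc12` gives in an ADME assay on L02 cells (Homo sapiens) for cytotoxicity, read by MTT assay, with a stated time of 48 h (a higher number here means a weaker inhibitor, a lower number a stronger inhibitor), a limit, > 300000 nM.
Compound 2 `Cc1ccc(Cn2cc(COc3ccc4c(=O)ccoc4c3)nn2)cc1` gives a limit, > 300000 nM.
Compound 3 `O=c1ccoc2cc(OCc3cn(Cc4cccc(Cl)c4)nn3)ccc12` gives a limit, > 300000 nM.

Compound 3 thus stands at the ceiling of what this assay reports, where all three measured compounds sit (the limit of > 300000 nM in this assay, at which 3 of the 3 values shown sit). Compound 4 `O=c1ccoc2cc(OCc3cn(Cc4ccccc4Br)nn3)ccc12` differs from compound 3 by 2-bromophenyl in place of 3-chlorophenyl on a saturated chain carbon bound to an aromatic nitrogen; cut one bond further out, 3-chlorobenzyl becomes 2-bromobenzyl. The three measured steps, a step that the two limits leave unreadable from compound 1 to compound 2, a step that the two limits leave unreadable from compound 1 to compound 3 and a step that the two limits leave unreadable from compound 2 to compound 3, each join two limits, so none has a readable size. For the measured compounds named here, no measured step therefore points to a change beyond the scatter, and compound 4 is expected to return a limit as well, a number no higher from compound 3 to compound 4 (the limit leaves the size open). The estimate for compound 4 is 300000 nM, between 150000 nM and 600000 nM.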

Compound 4, half-maximal inhibitory concentration: > 300000 nM
Compound 4: a limit, no number; the forecaster's own chance of this, stated with the estimate: 85%; the middle value lies on the limit itself.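

For the compounds shown here, compound 4, like compound 1, compound 2 and compound 3, gives only a limit, so no step among them can be read: the limit of > 300000 nM in this assay, at which 4 of the 4 values shown sit.

The compounds shown leave open whether changing the benzyl group alters the result in this assay at all.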